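Adding a second methoxy to compound 1

The compounds below may be only part of what the source reports. "The series", "measured", "known", "first", "only" and "open" are said of these compounds alone.

Compound 1 `COc1ccc(-c2cccc(O)c2)cc1`: 48 ug/mL
Compound 2 `Nc1ccc(-c2cccc(O)c2)cc1`: > 100 ug/mL
Compound 3 `COc1ccc(-c2cccc(O)c2)cc1OC`: not yet measured

Going by the values given here, in a functional assay on MCF7 cells (Homo sapiens) for cytotoxicity, read by MTT assay, with a stated time of 3 days (on this read-out lower numbers stand for stronger inhibition and higher numbers for weaker inhibition), compound 1 gives 48 ug/mL, the only actual number so far. Compound 2 gives > 100 ug/mL, which is a limit of the assay. Compound 3 differs from compound 1 by methoxy in place of hydrogen on an aromatic carbon. Among the compounds with values here, the only measured step, an at least 2.0-fold higher number from compound 1 to compound 2 (0.31 log units; beyond the scatter), lies beyond the scatter, but it replaces the methoxy group that compound 3 keeps. It therefore bears only loosely on this change, and no step beyond the scatter is expected, in either direction. The estimated step is a 1.1-fold lower number from compound 1 to compound 3 (0.03 log units; within the scatter). The expected value for compound 3 is 45 ug/mL, with an estimated range of 18 ug/mL to 100 ug/mL.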

Compound 3, half-maximal inhibitory concentration: 48 ug/mL
Beside the measured number, compound 3's estimate is 1.1-fold (0.03 log units) below it; low and high end bracket the measured number.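

In this assay, the position ortho to a methoxy group accepts a second methoxy, with no change at the digits printed from compound 1 to compound 3 (within the scatter). The earlier step changed the existing methoxy group to amino, so it gave no reading of this position; this step keeps that group and adds to the shared core. Nothing in the data at hand bears on why the number stays put.

On these data alone, whether a carboxylic acid or a longer chain such as ethoxy at this position would shift the number remains open. Also open, as far as these compounds go, is what the hydroxy group of the shared core contributes.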